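Swapping Phenyl for Pyridin-2-yl on a Shared Core

This account rests on a few compounds, and the source may have more. Where it says the series, first, only, none or still open, it means among the compounds named here.

Compound 1 `Nc1n[nH]c2cc(-c3ccccn3)[nH]c(=O)c12`: 47%
Compound 2 `Cc1cc2c(c(N)nn2C)c(=O)[nH]1`: 3%
Compound 3 `Cn1nc(N)c2c(=O)[nH]c(-c3ccccc3)cc21`: 16%

Of the compounds shown here, three have been tested in an assay on isolated protein for inhibition of serine/threonine-protein kinase Chk2 (Homo sapiens), read by mobility shift assay, tested at 30 uM; a lower number here means less inhibition, a higher number more inhibition at the concentration tested (going by the name of the read-out). Compound 3 stands second of the three: compound 2 is nearest and gives 3%, while compound 1 is furthest and gives 47%, well above compound 3 on this assay. For the measured compounds named here, the one measured step between neighbours, a number 13 percentage points higher from compound 2 to compound 3 (beyond the scatter), is a modest gain.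

Compound 4 `Cn1nc(N)c2c(=O)[nH]c(-c3ccccn3)cc21` has not yet been measured. It differs from compound 3 in a single place: pyridin-2-yl in place of phenyl on an aromatic carbon. The measured step of a number 13 percentage points higher from compound 2 to compound 3 (beyond the scatter) concerns a different exchange, methyl for phenyl, and so does not speak directly to this change. Compound 1 carries a pyridin-2-yl group and gives 47%, but its core also differs from that of compound 4, so its number is only a loose hint. For compound 4 the expected step is a number 9 percentage points higher from compound 3 to compound 4 (within the scatter), a small rise at most, with a wide range. Compound 4 is therefore estimated at 25%, between 5% and 50%.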

Compound 4, a percentage reported as inhibition, at one concentration (the size of the read-out at that concentration, not a potency): 25%
Beside the measured number, compound 4's estimate shows no gap at the digits printed; low and high end bracket the measured number.
By their numbers in this assay, from the lowest: compound 2; then compounds 3 and 4 (each within the scatter of the next); then compound 1.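

On the shared core, pyridin-2-yl in place of phenyl gives a number 9 percentage points higher from compound 3 to compound 4 (within the scatter) in this assay and so, at this position, the added ring nitrogen makes no clear difference to the reading. With pyridin-2-yl as with phenyl, an aromatic ring reads above the methyl of compound 2, here as a number 22 percentage points higher from compound 2 to compound 4 (beyond the scatter) with that ring in place. For the compounds shown here, the same pyridin-2-yl also isolates a second place for the first time: methyl in place of hydrogen on the aromatic nitrogen gives a number 22 percentage points lower from compound 1 to compound 4 (beyond the scatter) on this otherwise unchanged structure.

On these data alone, whether pyridin-3-yl or a small amine at the ring position would read any differently remains open. No measurement shown accounts for either the size or the direction of these steps.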